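Replacing the hexyl chain of compound 3 with an oxirane-bearing group

The source may hold more compounds than are shown below. What is called first, only, known or untested is meant among the compounds shown, and "the series" means these compounds.

Compound 3 `CCCCCCc1cc(C(C)=O)c(O)cc1OCCCCC#N` gives 13% in an assay on isolated protein for binding affinity to leukotriene B4 receptor 1 (Homo sapiens), tested at 1 uM (on this read-out lower numbers stand for less inhibition and higher numbers for more inhibition at the one concentration tested (going by the name of the read-out)), the second highest of three numbers and within the scatter of compound 2 `CCCCCc1cc(C(C)=O)c(O)cc1OCCCCC#N`, which gives 14%, while compound 1 `CC(=O)c1ccc(OCCCCC#N)cc1O` gives 0%. Compound 4 `CC(=O)c1cc(CC2CO2)c(OCCCCC#N)cc1O` differs from compound 3 by oxiran-2-yl in place of pentyl on a saturated chain carbon bound to an aromatic carbon. The step that bears on it most is a number 13 percentage points higher from compound 1 to compound 3 (beyond the scatter), showing that the chain on the aromatic carbon carries the whole of the inhibition seen here, whereas a number 1 percentage points lower from compound 2 to compound 3 (within the scatter) shows that one more chain carbon changes nothing. Cutting the chain back to a three-atom group is therefore expected to cost part of that gain, a number 8 percentage points lower from compound 3 to compound 4 (within the scatter), so compound 4 is estimated at 5%, between 0% and 15%.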

Compound 4, a percentage reported as inhibition, at one concentration (the size of the read-out at that concentration, not a potency): 24%
Beside the measured number, compound 4's estimate is 19 percentage points below it, outside the stated range (above it).
By their numbers in this assay, from the lowest: compound 1; then compounds 3, 2 and 4 (each within the scatter of the next, the first and the last beyond it).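

In this assay, the group on this saturated chain carbon need not be a long alkyl chain: oxiran-2-yl, with fewer heavy atoms than pentyl and one hydrogen-bond acceptor, gives a number 11 percentage points higher from compound 3 to compound 4 (beyond the scatter) and, in place of butyl, a number 10 percentage points higher from compound 2 to compound 4 (within the scatter). As (oxiran-2-yl)methyl in place of hydrogen on the aromatic carbon, it gives a number 24 percentage points higher from compound 1 to compound 4 (beyond the scatter), so an all-carbon chain is not required there. Nothing measured here accounts for these steps. The compounds shown leave open whether the ring or its oxygen matters, as a cyclopropylmethyl group or a 2,3-dihydroxypropyl group at this position would show.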